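The source may hold more compounds than are shown below. What is called first, only, known or untested is meant among the compounds shown, and "the series" means these compounds.

Measured values in an ADME assay on Huh-7 cells (Homo sapiens) for cytotoxicity, read by MTT assay, with a stated time of 72 h; on this read-out higher numbers stand for lower toxicity in this test and lower numbers for higher toxicity in this test:

compound 1, `COc1cc(O)c(C(=O)/C=C/c2ccc(OCc3cn(-c4ccccc4Cl)nn3)c(OC)c2)c(OC)c1`: > 100 ug/mL, a limit of the assay
compound 2, `COc1cc(O)c(C(=O)/C=C/c2ccc(OC)c(OCc3cn(-c4ccc(F)cc4Cl)nn3)c2)c(OC)c1`: > 100 ug/mL, a limit of the assay
compound 3, `COc1cc(O)c(C(=O)/C=C/c2ccc(OCc3cn(-c4ccc(F)c(Cl)c4)nn3)c(OC)c2)c(OC)c1`: > 100 ug/mL, a limit of the assay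

Compound 3 therefore stands at the limit of this assay, and so do the other two values shown: the limit of > 100 ug/mL in this assay, at which 3 of the 3 values shown sit. For the measured compounds named here, the only single-point step among the measured compounds is a step that the two limits leave unreadable from compound 1 to compound 3; with both ends at the limit its size cannot be read. The change to compound 4, `COc1cc(O)c(C(=O)/C=C/c2ccc(OCc3cn(-c4ccc(F)cc4F)nn3)c(OC)c2)c(OC)c1`, is 2,4-difluorophenyl in place of 3-chloro-4-fluorophenyl on an aromatic nitrogen. Going by the values given here, no measured step bears on this exchange in a readable way, and all three values sit at the limit, so in this assay no shift beyond the scatter is expected, and a value at or near the limit is the most likely outcome for compound 4. Compound 4 is estimated at 100 ug/mL, with a range from 50 ug/mL to 200 ug/mL. The expected step is then a number no higher from compound 3 to compound 4 (the limit leaves the size open).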

Compound 4, half-maximal cytotoxic concentration: > 100 ug/mL
Compound 4: only a limit was reported; the forecaster's own chance of this, stated with the estimate: 80%; the middle value lies on the limit itself.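

In this assay, neither the step between compound 3 and compound 4 nor that between compound 1 and compound 4 can be read, as both ends of each are limits: the limit of > 100 ug/mL in this assay, at which 4 of the 4 values shown sit.

The compounds shown leave open whether exchanging these aryl groups changes this read-out at all.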